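Aryl variation on the enol side chain: compound 3

This account rests on a few compounds, and the source may have more. Where it says the series, first, only, none or still open, it means among the compounds named here.

Among the measured compounds shown here, compound 2 `COC1=C(C)C(=O)/C(=C(O)/C=C/c2ccccc2OC)C(=O)C1(C)C` carries the lowest number of the two measured so far: in a functional assay on PC-3 cells (Homo sapiens) for cytotoxicity (a lower number here means that less compound is needed, a higher number that more compound is needed for the effect), compound 2 gives 15.6 ug/mL. Compound 1 `COC1=C(C)C(=O)/C(=C(O)/C=C/c2ccc(OC)cc2)C(=O)C1(C)C` is its nearest neighbour, and in this assay compound 1 gives 18.2 ug/mL; the step of a 1.2-fold lower number from compound 1 to compound 2 (0.07 log units; within the scatter) lies within the scatter, so no order between the two can be read from these numbers.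

Compound 3 `COC1=C(C)C(=O)/C(=C(O)/C=C/c2ccc(C)cc2)C(=O)C1(C)C` is the next candidate. Its change from compound 2: 4-methylphenyl in place of 2-methoxyphenyl on a double-bonded chain carbon bound to a double-bonded chain carbon. For the measured compounds named here, only one measured step bears on this change, namely a 1.2-fold lower number from compound 1 to compound 2 (0.07 log units; within the scatter), and it sits within the scatter. Going by the values given here, no measured pair speaks to the exchange of a methoxy-bearing ring for a methyl-bearing one, so that part of the change has no precedent. The expectation in this assay is thus a step of no more than the scatter, in either direction, with the range widened to cover the untested exchange.

Compound 3 is expected to give 17 ug/mL in this assay, within 8 ug/mL to 36 ug/mL. The step expected from this estimate is a 1.1-fold higher number from compound 2 to compound 3 (0.04 log units; within the scatter).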

Compound 3, concentration for half-maximal effect: 8.2 ug/mL
For compound 3 the middle estimate is 2.1-fold (0.32 log units) above the measured one; measured number inside the range.
By their numbers in this assay, from the lowest: compounds 3, 2 and 1 (each within the scatter of the next, the first and the last beyond it).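

Among the compounds shown here, the exchange of methoxy for methyl on an aromatic carbon gives the first step that clears the scatter in this assay: a 2.2-fold lower number from compound 1 to compound 3 (0.35 log units; beyond the scatter), so this aromatic substituent can shift the number, if only by a small margin. For the compounds shown here, the change from 2-methoxyphenyl to 4-methylphenyl on a double-bonded chain carbon bound to a double-bonded chain carbon gives a 1.9-fold lower number from compound 2 to compound 3 (0.28 log units; within the scatter), and no order can be read between these two compounds, so compound 1 and compound 3 form the only pair so far that separates. No measurement on hand offers an explanation for either step.

The aromatic substituents shown are limited to methoxy and methyl, so it remains open whether a chlorine atom, a hydroxyl group or an amine on the same ring would continue this direction or reverse it. On these data alone, whether the methyl-for-methoxy step, small as it is, would hold up in any read-out other than this assay also remains open.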